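Anilino-capped hydroxamates: 4-methoxyphenyl as cap group

The compounds below may be only part of what the source reports. "The series", "measured", "known", "first", "only" and "open" are said of these compounds alone.

Measured compounds:
Compound 1, `COc1ccc(Nc2ncnc3cc(NC(=O)CCCCCCC(=O)NO)sc23)c(C)c1` — 111 nM
Compound 2, `CCc1cccc(Nc2ncnc3cc(NC(=O)CCCCCCC(=O)NO)sc23)c1` — 58.5 nM

In an assay on cells for inhibition of protein deacetylase HDAC6 (Homo sapiens), with a stated time of 3 h (a lower number here means a stronger inhibitor, a higher number a weaker inhibitor), compound 1 gives 111 nM, and compound 2 gives 58.5 nM. Compound 2 therefore holds the lowest of the two numbers, but the step of a 1.9-fold lower number from compound 1 to compound 2 (0.28 log units; within the scatter) is within the scatter, so the two compounds cannot be ordered.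

Compound 3, `COc1ccc(Nc2ncnc3cc(NC(=O)CCCCCCC(=O)NO)sc23)cc1`, is not yet measured. It differs from compound 2 in one place: 4-methoxyphenyl in place of 3-ethylphenyl on a nitrogen on an aromatic ring. Among the compounds with values here, the one measured step that bears on this change is a 1.9-fold lower number from compound 1 to compound 2 (0.28 log units; within the scatter), which replaced a 4-methoxy-2-methylphenyl by a 3-ethylphenyl and stayed within the scatter. Compound 3 carries a 4-methoxyphenyl, which resembles the 4-methoxy-2-methylphenyl of compound 1 more closely than the 3-ethylphenyl of compound 2 does, so the change back toward that pattern is expected to give no step beyond the scatter in this assay, with the number, if anything, drifting toward that of compound 1. The expected step is a 1.4-fold higher number from compound 2 to compound 3 (0.14 log units; within the scatter). For compound 3 the estimate in this assay is 80 nM, with a range from 35 nM to 180 nM.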

Compound 3, half-maximal inhibitory concentration: 71.4 nM
The estimate for compound 3 lay 1.1-fold (0.05 log units) above the measured number; low and high end bracket the measured number.
By their numbers in this assay, from the lowest: compounds 2, 3 and 1 (each within the scatter of the next).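

In this assay, 4-methoxyphenyl in place of 3-ethylphenyl on a nitrogen on an aromatic ring gives a 1.2-fold higher number from compound 2 to compound 3 (0.09 log units; within the scatter), so these two groups cannot be told apart here, although the entering group counts a hydrogen-bond acceptor and the leaving group none. Compound 3 also isolates a single change that the earlier pair did not, hydrogen in place of methyl on an aromatic carbon, and this gives a 1.6-fold lower number from compound 1 to compound 3 (0.19 log units; within the scatter). All three compounds therefore lie within the scatter of one another, and none of the changes shown at this nitrogen separates them. Nothing beyond these numbers is available to account for them.

The compounds shown leave open whether any group on this phenyl ring can move the number beyond the scatter, for example an amine or a carboxylic acid in place of the methoxy group. They also leave open how the number responds to a shorter or longer chain ahead of the hydroxamic acid, since that chain is the same in all three compounds.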